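The source may hold more compounds than are shown below. What is called first, only, known or untested is meant among the compounds shown, and "the series" means these compounds.

Of the compounds shown here, three have so far been measured in a functional assay, with a stated time of 150 min; on this read-out lower numbers stand for stronger inhibition and higher numbers for weaker inhibition. Compound 1 `CN(C)c1ccc(-c2nc(NN)n(C)c(=O)c2C#N)cc1` gives 69 ug/mL. Compound 3 `Cn1c(NN)nc(-c2cccs2)c(C#N)c1=O` gives 63 ug/mL, and compound 2 `CSc1nc(-c2cccs2)c(C#N)c(=O)n1C` gives 87 ug/mL. Compound 3 and compound 2 differ in a single place: methylsulfanyl in place of aminoamino on an aromatic carbon That change made a step of a 1.4-fold higher number from compound 3 to compound 2 (0.14 log units; within the scatter).

Compound 4 `CSc1nc(-c2ccc(N(C)C)cc2)c(C#N)c(=O)n1C` has not yet been measured; it arises from compound 1 by the same kind of change: methylsulfanyl in place of aminoamino on an aromatic carbon The difference between the core of compound 1 and the core of compound 3 is not broken down here. Around the changed place the two settings are not identical: in compound 1 the place is meta to a group of 9 heavy atoms, whereas in compound 3 it is meta to a thiophen-2-yl group (5 heavy atoms), so the change is the same kind of change, not the same.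

A step of about the same size is expected here, a 1.4-fold higher number from compound 1 to compound 4 (0.14 log units; within the scatter), because the earlier step of a 1.4-fold higher number from compound 3 to compound 2 (0.14 log units; within the scatter) stayed within the scatter. Compound 4 is therefore estimated at 95 ug/mL, with a likely range from 50 ug/mL to 180 ug/mL.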

Compound 4, half-maximal inhibitory concentration: 93 ug/mL
The estimate for compound 4 lay 1.0-fold (0.01 log units) above the measured number, and the stated range covers the measured number.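

In this assay, putting methylsulfanyl in place of aminoamino on the core of compound 1 gave a 1.3-fold higher number from compound 1 to compound 4 (0.13 log units; within the scatter). Set beside the earlier case, the same kind of change gave matching steps on the two cores: the same change on two cores in this assay, a 1.4-fold higher number (0.14 log units; within the scatter) from compound 3 to compound 2 and a 1.3-fold higher number (0.13 log units; within the scatter) from compound 1 to compound 4, 1.0-fold (0.01 log units) apart, within the scatter of two such steps Both steps lie within the usual scatter, so the match shows only that nothing distinguishes the two cores here; it does not show that the change truly moves the read-out, and two cores cannot speak for every other core in the series.

The compounds shown carry only aminoamino or methylsulfanyl at this place, so it remains open whether another group there, such as a simple amine, a hydroxyl group or a longer alkylsulfanyl chain, would give a step beyond the scatter. As far as these compounds go, it also remains open whether the change would behave the same way if something else, such as a carboxylic acid, stood in place of the cyano group.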